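The compounds below may be only part of what the source reports. "The series", "measured", "known", "first", "only" and "open" are said of these compounds alone.

Measured in a functional assay on HepG2 cells (Homo sapiens), read by MTT assay, with a stated time of 48 h; on this read-out higher numbers stand for weaker inhibition and lower numbers for stronger inhibition:
- compound 1 `CCN(CC)CCCNC(=O)c1ccc(C(CC)(CC)c2ccc(OCC(=O)C(C)(C)C)c(C)c2)n1CC`: 180 nM
- compound 2 `C#CCNC(=O)c1ccc(C(CC)(CC)c2ccc(OCC(O)C(C)(C)C)c(C)c2)n1CC`: > 50000 nM

Compound 1 is the only one of the two with a true number, and it differs from compound 2 in more than one place, so no single structural change can be read from this pair.

For compound 2, the reading > 50000 nM is a limit of the assay and not a number. Compound 2 thus stands at the limit of > 50000 nM in this assay, at which 1 of the 2 values shown sits.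

The next compound, compound 3 `CC[C@@H](C)[C@H](NC(=O)c1ccc(C(CC)(CC)c2ccc(OCC(O)C(C)(C)C)c(C)c2)n1CC)C(=O)O`, keeps the rest of compound 2 and changes one group: 1-carboxy-2-methylbutyl in place of propargyl on an amide-type nitrogen. Going by the values given here, no measured compound carries this new group, so there is no direct guide to its effect.

The starting point is compound 2, whose > 50000 nM is a limit, and no step beyond the usual scatter is expected in this assay, in either direction. The reading will most likely stay at the limit. The expected step is a number no higher from compound 2 to compound 3 (the limit leaves the size open). For compound 3 the estimated value is 50000 nM, with an expected range of 20000 nM to 100000 nM.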

Compound 3, half-maximal inhibitory concentration: 127 nM
The estimate for compound 3 lay 390-fold (2.60 log units) above the measured number, outside the stated range (below it).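

In this assay, the group on this amide-type nitrogen proves able to move the read-out a long way: replacing propargyl with 1-carboxy-2-methylbutyl gives an at least 390-fold lower number from compound 2 to compound 3 (2.59 log units; beyond the scatter). The reading for compound 2 is a limit of the assay and not a number: the limit of > 50000 nM in this assay, at which 1 of the 3 values shown sits. Going by these compounds alone, the rest of the structure is shared by the pair, and compound 3 reaches a true number of 127 nM with only this one group changed. This shared part therefore does not by itself keep a compound at the limit.

The new group brings several features at once, including a carboxylic acid, a branched carbon chain and 2 defined stereocentres, and the compounds shown cannot tell which of these accounts for the step. On these data alone, a methyl ester in place of the carboxylic acid, a plain branched alkyl chain with no carboxylic acid, or the same group with its stereocentres inverted would each separate these features, and how far the step depends on any one of them remains open.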